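Replacing a nitro-bearing ring with a bromophenyl on a sulfonyl enone

A few compounds are considered here, and "the series" means these few. Any claim that something is new, unique, unknown or untested is made for them only; others in the source may bear on it.

Compound 1, `O=C(/C(=C\c1ccc(Br)cc1)S(=O)(=O)c1ccc(Br)cc1)c1ccc(Br)cc1`: 10000 nM
Compound 2, `O=C(/C(=C\c1cc([N+](=O)[O-])ccc1F)S(=O)(=O)Cc1ccc(F)cc1)c1ccc(Br)cc1`: > 100000 nM

Compound 1 was tested in a functional assay on DU-145 cells (Homo sapiens) for inhibition, read by trypan blue exclusion, with a stated time of 96 h (on this read-out lower numbers stand for stronger inhibition of growth and higher numbers for weaker inhibition of growth), and gives 10000 nM. Compound 2 gives only a limit in this assay, > 100000 nM, so its true value is not known; (the limit of > 100000 nM in this assay, at which 1 of the 2 values shown sits). Compound 3, `O=C(/C(=C\c1ccc(Br)cc1)S(=O)(=O)Cc1ccc(F)cc1)c1ccc(Br)cc1`, is not yet measured. It differs from compound 2 by 4-bromophenyl in place of 2-fluoro-5-nitrophenyl on a double-bonded chain carbon bound to a double-bonded chain carbon. Compound 1 and compound 2 differ in two places, so no single step between them is shown; their values only show that compound 1 gives a number and compound 2 a limit. Compound 3 shares its enone-bearing ring with compound 1 and its sulfonyl-bearing group with compound 2. Since compound 2 stands at a limit, the step of an at least 3.3-fold lower number from compound 2 to compound 3 (0.52 log units; beyond the scatter) is expected to run toward stronger inhibition, but its size is uncertain. For compound 3 the estimate in this assay is 30000 nM, between 8000 nM and 100000 nM.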

Compound 3, concentration for 50% growth inhibition: 25000 nM
Compound 3: the middle estimate sits 1.2-fold (0.08 log units) above what was measured; the range from low to high includes it.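

In this assay, 4-bromophenyl on a double-bonded chain carbon bound to a double-bonded chain carbon gives an at least 4.0-fold lower number from compound 2 to compound 3 (0.60 log units; beyond the scatter), so with the 4-fluorobenzyl group kept on the sulfonyl sulfur, this position now yields a number where 2-fluoro-5-nitrophenyl yielded only a limit. Among these compounds, the change on the sulfonyl sulfur can also be read alone for the first time, and 4-fluorobenzyl in place of 4-bromophenyl gives a 2.5-fold higher number from compound 1 to compound 3 (0.40 log units; beyond the scatter), a modest weakening of growth inhibition. The true size of the first step remains unknown: the limit of > 100000 nM in this assay, at which 1 of the 3 values shown sits.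

From the compounds shown here alone, whether the nitro group or the fluorine of the departing ring matters more for that step remains open. So does how this assay would read with an amine or a carboxylic acid on the ring at this position.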